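Swapping the methyl position on the pyridinyl arm

This account rests on a few compounds, and the source may have more. Where it says the series, first, only, none or still open, it means among the compounds named here.

Measured compounds:
compound 1 `Cc1cccc(/C(N)=N/NC(=S)N2CCN(c3ccccn3)CC2)n1`, 34.3%
compound 2 `N/C(=N\NC(=S)N1CCCCCC1)c1ccccn1`, 50.3%
compound 3 `Cc1ccnc(/C(N)=N/NC(=S)N2CCOCC2)c1`, 35.5%

In a functional assay on A-431 cells (Homo sapiens) for cytotoxicity, read by MTT assay, with a stated time of 72 h, tested at 3 uM (a lower number here means less inhibition of growth, a higher number more inhibition of growth at the concentration tested), compound 1 gives 34.3%, the lowest of the three numbers. Its nearest neighbour is compound 3, which gives 35.5%; the two values lie within the usual scatter of the assay, so nothing can be said about which of them inhibits growth more. Compound 2 gives 50.3%, a number beyond the scatter above that of compound 1, so compound 2 is the only one of the three that clearly inhibits growth more than compound 1 does.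

Compound 4 `Cc1ccnc(/C(N)=N/NC(=S)N2CCN(c3ccccn3)CC2)c1` has not yet been measured. The change from compound 1 is 4-methylpyridin-2-yl in place of 6-methylpyridin-2-yl on a carbon with a double bond to nitrogen. The same pyridinyl arm appears in compound 3, which, paired with a different amine, gives a value indistinguishable from that of compound 1. For the measured compounds named here, no measured pair shows this swap on its own, so the size of the step rests on that comparison alone. The step from compound 1 to compound 4 in this assay is expected to be a number 2.7 percentage points higher from compound 1 to compound 4 (within the scatter), that is, nothing beyond the scatter. For compound 4 the estimated value in this assay is 37%, with a range from 25% to 50%.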

Compound 4, percent growth inhibition at one concentration: 34.7%
Compound 4: middle estimate off by 2.3 percentage points, on the high side, and the stated range covers the measured number.
By their numbers in this assay, from the lowest: compounds 1, 4 and 3 (each within the scatter of the next); then compound 2.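

The swap of 6-methylpyridin-2-yl for 4-methylpyridin-2-yl, on a carbon with a double bond to nitrogen, now has a direct reading: in this assay the step is a number 0.4 percentage points higher from compound 1 to compound 4 (within the scatter) and nothing else in the molecule changes. The earlier compounds shown here formed no such pair, so only now can it be said that, with this amine, relocating the methyl from one of these two named arms to the other gives no detectable change in growth inhibition at the concentration tested. No measurement is at hand that would tie this outcome to any property of either arm.

The compounds shown leave open whether the same holds with the other amines in the set, as only this one amine carries both arms. They also leave open what happens when the methyl on the pyridinyl arm gives way to a different group, such as a methoxy group, a chlorine atom or an ethyl chain.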